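The compounds below may be only part of what the source reports. "The series", "measured", "known", "first", "only" and "open" are said of these compounds alone.

In a functional assay on NCI-H460 cells (Homo sapiens) for inhibition, read by MTT assay, with a stated time of 4 days (a higher number here means a weaker inhibitor, a lower number a stronger inhibitor), compound 2 `COc1cc(NC(C)CCCNC(=O)NNC(=O)NCCO)c2ncccc2c1` gives > 100000 nM, which is a limit of the assay and not a number. Compound 1 `COc1cc(NC(C)CCCNC(=O)NNC(=O)Nc2ccc(Cl)c(C(F)(F)F)c2)c2ncccc2c1` carries 4-chloro-3-(trifluoromethyl)phenyl on the same amide-type nitrogen and gives 13000 nM. Among the measured compounds shown here, the only measured step, an at least 7.6-fold higher number from compound 1 to compound 2 (0.88 log units; beyond the scatter), is a clear loss of activity. Compound 3 `COc1cc(NC(C)CCCNC(=O)NNC(=O)NC(CO)(CO)CO)c2ncccc2c1` has 2-hydroxy-1,1-bis(hydroxymethyl)ethyl in place of 2-hydroxyethyl (2-hydroxy-1,1-bis(hydroxymethyl)ethyl in place of 2-hydroxyethyl on an amide-type nitrogen). Neither group has a ring, so the ring-bearing group lost in an at least 7.6-fold higher number from compound 1 to compound 2 (0.88 log units; beyond the scatter) is not restored. The expected change is none beyond the scatter, a step that the limit leaves unreadable from compound 2 to compound 3. Compound 3 is estimated at 120000 nM, within 40000 nM to 300000 nM, and is expected to read as a limit too.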

Compound 3, half-maximal inhibitory concentration: > 100000 nM
Compound 3: a limit, no number; the forecaster's own chance of this, stated with the estimate: 80%; the middle value lies beyond the limit too.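

Compound 3 reads as a limit of the assay and not a number: the limit of > 100000 nM in this assay, at which 2 of the 3 values shown sit. So the loss on this amide-type nitrogen is not particular to 2-hydroxyethyl: a second ring-free group, 2-hydroxy-1,1-bis(hydroxymethyl)ethyl, shows an at least 7.6-fold higher number from compound 1 to compound 3 (0.88 log units; beyond the scatter). The step between the two ring-free compounds cannot be read, as both values are limits.

From the compounds shown here alone, it remains open whether the ring or the chloro and trifluoromethyl groups carry the activity of compound 1. An unsubstituted phenyl, or a longer chain without hydroxyl groups, on this nitrogen would help separate these possibilities.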